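The source may report more compounds than this note shows. Statements on the series, on what has been measured and on what is new or still open speak of the compounds shown alone.

Of the compounds shown here, three that share one core have been measured in an assay on HEK293 cells for activation of Kir3.1/Kir3.2 (Homo sapiens), read by thallium flux; on this read-out lower numbers stand for an effect already at smaller amounts and higher numbers for an effect only at larger amounts of compound. Compound 1 `Cc1cc(NC(=O)Cn2nnc(-c3ccccc3F)n2)n(C2CCCCC2)n1` carries a 2-fluorophenyl group on an aromatic carbon, and in this assay compound 1 gives 187 nM. Compound 2 `Cc1cc(NC(=O)Cn2nnc(-c3ccc(F)c(F)c3)n2)n(C2CCCCC2)n1` carries a 3,4-difluorophenyl group in its place; in this assay compound 2 gives 116 nM, which is a 1.6-fold lower number from compound 1 to compound 2 (0.21 log units; within the scatter). Compound 3 `Cc1cc(NC(=O)Cn2nnc(C3CC3)n2)n(C2CCCCC2)n1` carries a cyclopropyl group on that aromatic carbon. For compound 3 this assay reports only a limit, > 3000 nM, so its actual number is not known and it sits at the limit of > 3000 nM in this assay, at which 1 of the 3 values shown sits. Both steps leading to compound 3 are large: an at least 16-fold higher number from compound 1 to compound 3 (1.20 log units; beyond the scatter) and an at least 25-fold higher number from compound 2 to compound 3 (1.41 log units; beyond the scatter).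

Compound 4 `Cc1cc(NC(=O)Cn2nnc(-c3cccc(C#N)c3)n2)n(C2CCCCC2)n1` has not yet been measured. It differs from compound 3 by 3-cyanophenyl in place of cyclopropyl on an aromatic carbon. This change runs in the opposite direction to the two large steps just described, in which a cyclopropyl group replaced a fluorinated phenyl group and the number rose well beyond the scatter. Reversing that direction, a large move to a lower number is expected for compound 4 in this assay, a step of an at least 18-fold lower number from compound 3 to compound 4 (1.27 log units; beyond the scatter). The estimate for compound 4 is 160 nM, with a range from 50 nM to 600 nM.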

Compound 4, half-maximal effective concentration: 183 nM
Compound 4: middle estimate off by 1.1-fold (0.06 log units), on the low side; the range from low to high includes it.
By their numbers in this assay, from the lowest: compounds 2, 4 and 1 (each within the scatter of the next). At a limit, above all of these: compound 3.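

With 3-cyanophenyl, a phenyl group carrying a nitrile instead of fluorine now sits on this aromatic carbon, and the result in this assay stays within the scatter of both fluorinated compounds (a 1.6-fold higher number from compound 2 to compound 4 (0.20 log units; within the scatter); a 1.0-fold lower number from compound 1 to compound 4 (0.01 log units; within the scatter)). The three phenyl groups shown, 2-fluorophenyl, 3,4-difluorophenyl and 3-cyanophenyl, therefore give numbers that cannot be told apart here, even though their substituents differ in kind and in place on the phenyl ring. The large gap to the cyclopropyl compound also appears with a phenyl group that holds no fluorine (an at least 16-fold lower number from compound 3 to compound 4 (1.21 log units; beyond the scatter)), so fluorine is not needed to close it.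

Going by these compounds, the value for compound 3 is a limit, so the true size of that gap stays unknown: the limit of > 3000 nM in this assay, at which 1 of the 4 values shown sits. Also open is how this carbon would tolerate a group outside the two kinds shown, such as a longer alkyl chain, a cyclohexyl ring, or a phenyl ring bearing an amine or a carboxylic acid.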